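A few compounds are considered here, and "the series" means these few. Any claim that something is new, unique, unknown or untested is made for them only; others in the source may bear on it.

Compound 1, `Nc1ncc(-c2ccncc2-c2ccccc2)c(C2CC2)n1`: > 100000 nM, a limit of the assay.
Compound 2, `Nc1ncc(-c2ccncc2-c2ccoc2)c(C2CC2)n1`: 28000 nM.
Compound 3, `Nc1ncc(-c2ccncc2)c(-c2ccccc2)n1`: > 100000 nM, a limit of the assay.

All three were tested in a functional assay on CUTLL1 cells (Homo sapiens) for inhibition, read by resazurin assay, with a stated time of 48 h, in the presence of a further agent that is not named here; a lower number here means that less compound is needed, a higher number that more compound is needed for the effect. Compound 1 and compound 2 differ in one place: furan-3-yl in place of phenyl on an aromatic carbon. This gives an at least 3.5-fold lower number from compound 1 to compound 2 (0.55 log units; beyond the scatter). Only a lower bound on the size of that step is known because of the limit of > 100000 nM in this assay, at which 2 of the 3 values shown sit.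

Compound 4, `Nc1ncc(-c2ccncc2)c(-c2ccoc2)n1`, has not yet been measured in this assay. It differs from compound 3 in the same way: furan-3-yl in place of phenyl on an aromatic carbon. The surroundings differ, though: in compound 1 the change sits on a ring with 1 nitrogen, ortho to a large group and two atoms from the ring nitrogen, whereas in compound 3 it sits on a ring with 2 nitrogen, next to the ring nitrogen, ortho to a pyridin-4-yl group and meta to an amino group, so this is the same kind of change rather than the same change. The difference between the two cores is not broken down here.

Resting on compound 1 to compound 2, the expected step is an at least 2.0-fold lower number from compound 3 to compound 4 (0.30 log units; that floor lies within the scatter). Compound 4 is estimated at 50000 nM, between 12000 nM and 200000 nM.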

Compound 4, half-maximal effective concentration: > 100000 nM
Compound 4: only a limit was reported; the forecaster's own chance of this, stated with the estimate: 45%; middle value at least 2.0-fold (0.30 log units) away from the limit.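

Compound 3 and compound 4 both sit at a limit of this assay, so no step between them can be read: the limit of > 100000 nM in this assay, at which 3 of the 4 values shown sit.

The compounds shown leave open whether furan-3-yl in place of phenyl lowers the number at all on the core of compound 3, as it does on the core of compound 1.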